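Replacing ethoxy with methylamino in compound 3

This account rests on a few compounds, and the source may have more. Where it says the series, first, only, none or still open, it means among the compounds named here.

In an ADME assay on HeLa cells (Homo sapiens) for cytotoxicity, read by crystal violet staining, with a stated time of 72 h (on this read-out higher numbers stand for lower toxicity in this test and lower numbers for higher toxicity in this test), compound 1 `CCOC(=O)c1cc(CCCOc2ccc(-c3noc(C(F)(F)F)n3)cc2C)on1` gives 35100 nM. Compound 2 `CCOC(=O)c1cc(CCCOc2ccc(-c3noc(C(F)(F)F)n3)cc2OC)on1` gives > 100000 nM, which is a limit of the assay and not a number. Compound 3 `CCOC(=O)c1cc(CCCOc2ccc(-c3noc(C(F)(F)F)n3)cc2C(F)(F)F)on1` gives 28400 nM. The measured change here is a 1.2-fold lower number from compound 1 to compound 3 (0.09 log units; within the scatter), so these two numbers cannot be told apart.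

Compound 4 `CNC(=O)c1cc(CCCOc2ccc(-c3noc(C(F)(F)F)n3)cc2C(F)(F)F)on1` keeps the rest of compound 3 and carries methylamino in place of ethoxy on a carbonyl carbon. Among the compounds with values here, no measured step touches that carbonyl carbon. Within the data shown here, the other two steps, an at least 2.8-fold higher number from compound 1 to compound 2 (0.45 log units; beyond the scatter) and an at least 3.5-fold lower number from compound 2 to compound 3 (0.54 log units; beyond the scatter), are swaps on an aromatic carbon, so they show only that a single change can move this number. They give no direct size or direction for the new change. The expected result is therefore no step beyond the scatter, written as a 1.4-fold higher number from compound 3 to compound 4 (0.15 log units; within the scatter). For compound 4, the estimate is 40000 nM, with an expected range from 12000 nM to 100000 nM.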

Compound 4, half-maximal cytotoxic concentration: > 100000 nM
Compound 4 gave a limit, no number (the forecaster's own chance of this, stated with the estimate: 20%); middle value at least 2.5-fold (0.39 log units) from the limit.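

Within the data shown here, until now, no step had touched this carbonyl carbon, and the swap of ethoxy for methylamino in this assay now shows that a change here can move the number, giving an at least 3.5-fold higher number from compound 3 to compound 4 (0.54 log units; beyond the scatter) on the core that carries trifluoromethyl. The direction is towards lower toxicity in this test, so a change at the carbonyl carbon can shift the result just as the earlier swaps on the aromatic carbon did. Compound 4 gives > 100000 nM, which is a limit of the assay, so the true size of this step cannot be read: the limit of > 100000 nM in this assay, at which 2 of the 4 values shown sit.

Going by these compounds, it remains open whether the same swap gives a similar step on the core of compound 1, which carries methyl. Also open, on these data alone, is how a carboxylic acid or a longer amine such as ethylamino would behave on this carbonyl carbon.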